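Trifluoromethyl for Cyclopropyl on a Phenol Amide

The compounds below may be only part of what the source reports. "The series", "measured", "known", "first", "only" and "open" are said of these compounds alone.

Compound 1 `N#Cc1cc(C(=O)N2CCc3ccccc32)ccc1O`: 2500 nM
Compound 2 `N#Cc1cc(C(=O)N2CCc3ccccc32)cc(C2CC2)c1O`: 8800 nM

Among the compounds with values here, in an assay on tissue (RPTEC cells) for inhibition of solute carrier family 22 member 12 (Homo sapiens), read by scintillation counting, with stated times of 15 min and 2 h (a higher number here means a weaker inhibitor, a lower number a stronger inhibitor), compound 2 stands at the higher of the two numbers, with compound 1 giving the lower one, and a 3.5-fold higher number from compound 1 to compound 2 (0.55 log units; beyond the scatter) is the only measured step. Compound 3 `N#Cc1cc(C(=O)N2CCc3ccccc32)cc(C(F)(F)F)c1O` differs from compound 2 by trifluoromethyl in place of cyclopropyl on an aromatic carbon. The step from compound 1 to compound 2 bears on this only indirectly: it shows that adding cyclopropyl there raises the number, but nothing shows how trifluoromethyl compares with cyclopropyl. Compound 3 is therefore expected to change little, a 1.3-fold lower number from compound 2 to compound 3 (0.10 log units; within the scatter), within the scatter. The estimate for compound 3 is 7000 nM, ranging from 3000 nM to 16000 nM.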

Compound 3, half-maximal inhibitory concentration: > 100000 nM
Compound 3: only a limit was reported; the forecaster's own chance of this, stated with the estimate: 5%; middle value at least 14-fold (1.15 log units) from the limit.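

Compound 3 carries only a limit of the assay, not a number: the limit of > 100000 nM in this assay, at which 1 of the 3 values shown sits.

Trifluoromethyl in place of cyclopropyl, ortho to a hydroxy group, gives an at least 11-fold higher number from compound 2 to compound 3 (1.05 log units; beyond the scatter), so the two groups are not interchangeable at this position. Set against hydrogen, trifluoromethyl gives an at least 40-fold higher number from compound 1 to compound 3 (1.60 log units; beyond the scatter), which shows that this position tolerates cyclopropyl far better than trifluoromethyl.

Where a methyl group, a chlorine atom or a methoxy group would fall at this position remains open. So does the true value of compound 3 beyond its limit.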